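The source may hold more compounds than are shown below. What is called first, only, known or untested is meant among the compounds shown, and "the series" means these compounds.

The shared core of this small set is a sulfonate ester linking an aryl sulfonyl group to a phenol bearing an isopropyl group, with an acylated or urea-bearing amine on the sulfonyl-side ring. Compound 1 `CCCC(=O)Nc1cccc(S(=O)(=O)Oc2ccccc2C(C)C)c1` carries a butanamide and in a functional assay on M21 cells (Homo sapiens) for antiproliferative activity, read by sulforhodamine B assay, with a stated time of 48 h (on this read-out higher numbers stand for weaker inhibition and lower numbers for stronger inhibition), compound 1 gives 20000 nM. Compound 2 `CC(C)c1ccccc1OS(=O)(=O)c1cccc(NC(=O)CCl)c1` is its chloroacetamide counterpart; in this assay compound 2 gives 3900 nM. The change between them, (chloro in place of ethyl on a saturated chain carbon bound to a carbonyl carbon), produced a 5.1-fold lower number from compound 1 to compound 2 (0.71 log units; beyond the scatter).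

Compound 3 `CCCCCNC(=O)Nc1ccc(S(=O)(=O)Oc2ccccc2C(C)C)cc1` moves to a urea with a pentyl chain and shifts the substitution pattern of the sulfonyl-side ring; the difference between the core of compound 1 and the core of compound 3 is not broken down here. In this assay compound 3 gives 4600 nM, which sits close to the value of compound 2 and beyond the scatter from that of compound 1.

Compound 4 `CC(C)c1ccccc1OS(=O)(=O)c1ccc(NC(=O)NCCCCl)cc1` has not yet been measured. It differs from compound 3 by chloro in place of ethyl on a saturated chain carbon, three bonds along the chain from an amide-type nitrogen. This is the same kind of change as that from compound 1 to compound 2, but the place is not the same: there the chlorine entered on a saturated chain carbon bound to a carbonyl carbon, here it enters three bonds along the chain from an amide-type nitrogen. Because the earlier change gave a 5.1-fold lower number from compound 1 to compound 2 (0.71 log units; beyond the scatter), a lowering is expected here too, though a smaller one is estimated, since the place differs and a single precedent is all that is available. The step from compound 3 to compound 4 is estimated at a 2.3-fold lower number from compound 3 to compound 4 (0.36 log units; beyond the scatter). Compound 4 is expected to give about 2000 nM, estimated between 700 nM and 6000 nM.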

Compound 4, half-maximal inhibitory concentration: 9300 nM
Compound 4: middle estimate off by 4.7-fold (0.67 log units), on the low side, and the stated range ends below it.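

On the core of compound 3, the exchange of ethyl for chloro, three bonds along the chain from an amide-type nitrogen, gave a 2.0-fold higher number from compound 3 to compound 4 (0.31 log units; beyond the scatter) in this assay, so inhibition became weaker rather than stronger. Set beside the earlier step, this shows that in this series the change does not carry from one core to another as a fixed shift, or even in a fixed direction: the same change on two cores in this assay, a 5.1-fold lower number (0.71 log units; beyond the scatter) from compound 1 to compound 2 and a 2.0-fold higher number (0.31 log units; beyond the scatter) from compound 3 to compound 4, 10-fold (1.02 log units) apart, beyond the scatter of two such steps What this does not show is why the two steps part, for the cores differ and the chlorine stands in a different place in each pair, on a saturated chain carbon bound to a carbonyl carbon in one and three bonds along the chain from an amide-type nitrogen in the other, and a single pair on each core cannot separate these two differences.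

The compounds shown leave open whether a 2-chloroethyl or a chloromethyl group on the core of compound 3 would follow compound 4 or compound 2. They also leave open how a bromo group, a hydroxyl group or an amine in the chlorine's place would behave on either core.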